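This account rests on a few compounds, and the source may have more. Where it says the series, first, only, none or still open, it means among the compounds named here.

Compound 3, `CCCCCc1cc2cn(COCCO)c(=O)nc2o1`, carries a pentyl chain on the shared core. In a functional assay on HEL cells (Homo sapiens), read by microscopy (a lower number here means that less compound is tolerated, a higher number that more compound is tolerated), compound 3 gives only a limit, > 400000 nM. Compound 1, `CCCCc1cc2cn(COCCO)c(=O)nc2o1`, likewise gives a limit in this assay, > 400000 nM. Compound 2, `CCCCCCCCCc1cc2cn(COCCO)c(=O)nc2o1`, also gives a limit in this assay, >= 16000 nM. Compound 3 thus stands at the limit of > 400000 nM in this assay, at which 2 of the 3 values shown sit, whereas compound 2 sits at the limit of >= 16000 nM in this assay, at which 1 of the 3 values shown sits. Compound 4, `CCCCCCCCCCc1cc2cn(COCCO)c(=O)nc2o1`, differs from compound 3 by pentyl in place of hydrogen on a saturated chain carbon, five bonds along the chain from an aromatic carbon. The measured steps that bear on this change, a step that the two limits leave unreadable from compound 1 to compound 2 and a step that the two limits leave unreadable from compound 2 to compound 3, give no readable size, so no direction can be taken from them. Compound 4 is nevertheless expected to show an at least 25-fold lower number from compound 3 to compound 4 (1.39 log units; beyond the scatter). The estimate for compound 4 in this assay is 16000 nM, with a range from 4000 nM to 100000 nM.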

Compound 4, minimum cytotoxic concentration: 400000 nM
For compound 4 the middle estimate is 25-fold (1.40 log units) below the measured one; measured number outside the range, above it.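

In this assay, among these compounds, compound 4 gives 400000 nM, the first plain number in this set, so pentyl in place of hydrogen at this place yields a measured value and not a limit. Compound 3 remains a limit: the limit of > 400000 nM in this assay, at which 2 of the 4 values shown sit. The result shows a number no higher from compound 3 to compound 4 (the limit leaves the size open) and a number no higher from compound 1 to compound 4 (the limit leaves the size open), but none of the new steps has a readable size. On these data alone, it stays open how a longer chain, or a chain carrying an amine, would read in this assay. The limits also leave open whether chain length changes this number at all.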